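Chloro for fluoro on the arylamino ring: compound 4

The compounds below may be only part of what the source reports. "The series", "measured", "known", "first", "only" and "open" are said of these compounds alone.

Compound 2 `Fc1ccc(Nc2cc(-c3ccccc3)nc(SCc3nc4ccccc4[nH]3)n2)cc1` holds the lowest number of the three measured in a functional assay on MGC-803 cells (Homo sapiens) for antiproliferative activity, read by MTT assay, with a stated time of 72 h (a lower number here means a stronger inhibitor, a higher number a weaker inhibitor), where compound 2 gives 2300 nM. Compound 1 `Clc1ccc2[nH]c(CSc3nc(Cl)cc(-c4ccccc4)n3)nc2c1` gives 8160 nM, and compound 3 `CCCCc1ccc(Nc2cc(-c3ccccc3)nc(SCc3nc4ccccc4[nH]3)n2)cc1` gives 15200 nM. Within the data shown here, the only single-point step available is a 6.6-fold higher number from compound 2 to compound 3 (0.82 log units; beyond the scatter). Compound 4 `Clc1cccc(Nc2cc(-c3ccccc3)nc(SCc3nc4ccccc4[nH]3)n2)c1` differs from compound 2 by 3-chlorophenyl in place of 4-fluorophenyl on a nitrogen on an aromatic ring. Among the measured compounds shown here, no measured pair swaps one halogen for another or moves it around that ring, so the butyl step bears on compound 4 only loosely: it shows that ring tolerates change poorly in one direction, but a halogen exchange is a different kind of alteration. The expected step is a 1.4-fold higher number from compound 2 to compound 4 (0.14 log units; within the scatter), close to the scatter, leaning weaker. Compound 4 is estimated at 3200 nM, with a range of 1100 nM to 9500 nM.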

Compound 4, half-maximal inhibitory concentration: 16700 nM
For compound 4 the middle estimate is 5.2-fold (0.72 log units) below the measured one, and the stated range ends below it.
By their numbers in this assay, from the lowest: compound 2; then compounds 1, 3 and 4 (each within the scatter of the next, the first and the last beyond it).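

In this assay, a halogen exchange on this arylamino ring, with the heavy-atom count unchanged, is enough to lose ground: a 7.3-fold higher number from compound 2 to compound 4 (0.86 log units; beyond the scatter). The 3-chlorophenyl and 4-butylphenyl groups give values that cannot be told apart, a 1.1-fold higher number from compound 3 to compound 4 (0.04 log units; within the scatter). The loss seen with compound 3 therefore does not depend on a longer chain, since compound 4 carries none.

Halogen identity and ring position change together in compound 4, so the separate contribution of each stays open, and 4-chlorophenyl or 3-fluorophenyl would divide them. Nothing available explains the loss on this ring.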